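Aryl variation on the shared core: outlook for compound 4

This account rests on a few compounds, and the source may have more. Where it says the series, first, only, none or still open, it means among the compounds named here.

Measured so far in a functional assay on MCF7 cells (Homo sapiens) for cytotoxicity, read by MTT assay, with a stated time of 72 h; a lower number here means a stronger inhibitor, a higher number a weaker inhibitor:
- compound 1 `COc1c(OCCCCN2CCN(C)CC2)cc(O)c2c(=O)cc(-c3ccc(C(F)(F)F)cc3)oc12` gives 2980 nM
- compound 2 `COc1ccccc1-c1cc(=O)c2c(O)cc(OCCCCN3CCN(C)CC3)c(OC)c2o1` gives 5430 nM
- compound 3 `COc1c(OCCCCN2CCN(C)CC2)cc(O)c2c(=O)cc(-c3ccc(Br)cc3)oc12` gives 3210 nM

Compound 3 stands second highest of the three numbers. Its steps to the others, a 1.1-fold higher number from compound 1 to compound 3 (0.03 log units; within the scatter) and a 1.7-fold lower number from compound 2 to compound 3 (0.23 log units; within the scatter), both lie within the scatter, so the three aryl variants are not separated by these data.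

Compound 4 `COc1c(OCCCCN2CCN(C)CC2)cc(O)c2c(=O)cc(-c3ccc(F)cc3Br)oc12` differs from compound 3 by 2-bromo-4-fluorophenyl in place of 4-bromophenyl on an aromatic carbon. Among the compounds with values here, two measured steps bear on this change, since both alter only the aryl group at the same place: a 1.1-fold higher number from compound 1 to compound 3 (0.03 log units; within the scatter) exchanges one substituent for another on that ring, and a 1.7-fold lower number from compound 2 to compound 3 (0.23 log units; within the scatter) exchanges the whole aryl group including a substituent at a different position on it. Neither moved the number beyond the scatter. On this basis no step beyond the scatter is expected in this assay from compound 3 to compound 4, in either direction.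

Compound 4 is therefore estimated at 3400 nM, with a range of 1500 nM to 8000 nM. The expected step is a 1.1-fold higher number from compound 3 to compound 4 (0.02 log units; within the scatter), essentially flat.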

Compound 4, half-maximal inhibitory concentration: 3090 nM
For compound 4 the middle estimate is 1.1-fold (0.04 log units) above the measured one; measured number inside the range.
By their numbers in this assay, from the lowest: compounds 1, 4, 3 and 2 (each within the scatter of the next).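

In this assay the aromatic carbon next to the ring oxygen also accepts 2-bromo-4-fluorophenyl, an aryl group substituted at two ring positions, with no step beyond the scatter against 4-bromophenyl (a 1.0-fold lower number from compound 3 to compound 4 (0.02 log units; within the scatter)). The steps from the other two aryl variants (a 1.8-fold lower number from compound 2 to compound 4 (0.24 log units; within the scatter); a 1.0-fold higher number from compound 1 to compound 4 (0.02 log units; within the scatter)) also stay within the scatter, so bromo alongside fluoro on this ring does not separate compound 4 from the trifluoromethyl or methoxy variants. Nothing available explains why this position stays so flat across these aryl changes.

From the compounds shown here alone, whether an aryl group carrying an amine or a carboxylic acid would give a step beyond the scatter remains open. Also open, going by these compounds, is how a pyridyl ring in this position, or a shorter chain in place of the butyl linker, would compare.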